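Fluoro for hydrogen in a thiazolylidene hydrazide pair

The source may hold more compounds than are shown below. What is called first, only, known or untested is meant among the compounds shown, and "the series" means these compounds.

Measured so far:
- compound 1 `O=C(CSc1ncccn1)N/N=c1/scc(-c2ccccc2)n1-c1ccccc1` — "not determined" (no result reported) in a functional assay on C6 cells (Rattus norvegicus) for cytotoxicity, read by MTT assay, with a stated time of 24 h; on this read-out higher numbers stand for weaker inhibition and lower numbers for stronger inhibition
- compound 2 `O=C(CSc1nnnn1-c1ccccc1)N/N=c1/scc(-c2ccccc2)n1-c1ccccc1` — 8.3 ug/mL

Within the data shown here, compound 1 carries no number in this assay, its result being recorded as "not determined" (no result reported); it stands nowhere on the measured scale, and no step between the two measured compounds can be drawn. The only anchor in the series is compound 2, which in this assay gives 8.3 ug/mL. The pair of compounds 1 and 2 differ in more than one place, so their values say nothing about any single change.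

Compound 3 `O=C(CSc1ncccn1)N/N=c1/scc(-c2ccc(F)cc2)n1-c1ccccc1` differs from compound 1 by fluoro in place of hydrogen on an aromatic carbon. For a change of this size, in this assay no step beyond the usual scatter is expected, in either direction. With compound 1 unmeasured, the expectation for compound 3 rests only on the value of compound 2, taken as a rough level for the series. Compound 3 is therefore estimated at 10 ug/mL, with a range from 3 ug/mL to 40 ug/mL.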

Compound 3, half-maximal inhibitory concentration: 110 ug/mL
For compound 3 the middle estimate is 11-fold (1.04 log units) below the measured one, outside the stated range (above it).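

In this assay, among these compounds, compound 3 gives 110 ug/mL and compound 1 gives "not determined" (no result reported), so no step from compound 1 to compound 3 can be read. The compounds shown leave open what phenyl to 4-fluorophenyl does to the read-out. No evidence at hand bears on the result.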